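Removing One Trifluoromethyl from a Pyrazole Urea Series

This account rests on a few compounds, and the source may have more. Where it says the series, first, only, none or still open, it means among the compounds named here.

Compound 1 `O=C(Nc1cccc(-n2cc(-c3ccncc3)c(-c3cc(O)cc(Cl)c3)n2)c1)Nc1ccc(Cl)c(Cl)c1`: 26%
Compound 2 `COc1cc(Cl)cc(-c2nn(-c3cccc(NC(=O)Nc4ccc(Cl)c(C(F)(F)F)c4)c3)cc2-c2ccncc2)c1`: 30.2%
Compound 3 `COc1cc(Cl)cc(-c2nn(-c3cccc(NC(=O)Nc4cc(C(F)(F)F)cc(C(F)(F)F)c4)c3)cc2-c2ccncc2)c1`: 23%

Three ureas sharing one core were tested in a functional assay on IGROV-1 cells (Homo sapiens) for inhibition, read by sulforhodamine B assay, with a stated time of 48 h, tested at 10 uM; a higher number here means a weaker effect of the compound at the concentration tested, a lower number a stronger effect. Compound 1 gives 26%, compound 2 gives 30.2% and compound 3 gives 23%. Compound 3 shows the smallest number of the three, yet its gaps to compound 1 and to compound 2 both lie within the usual scatter, so the three readings cannot be ranked against one another.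

The next compound, compound 4 `COc1cc(Cl)cc(-c2nn(-c3cccc(NC(=O)Nc4cccc(C(F)(F)F)c4)c3)cc2-c2ccncc2)c1`, differs from compound 3 in a single place: hydrogen in place of trifluoromethyl on an aromatic carbon. Going by the values given here, no pair of measured compounds differs in exactly one place, so no measured step guides the expectation directly. Across compounds 1 to 3, changing the groups on the terminal ring moved the reading only within the scatter, and the change to compound 4 drops one such group. The expected step of a number 9 percentage points higher from compound 3 to compound 4 (within the scatter) is therefore small, if anything a slight rise in the number. Compound 4 is estimated at 32%, within 18% to 48%.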

Compound 4, a percentage reported as activity, at one concentration (the size of the read-out at that concentration, not a potency): 28.9%
For compound 4 the middle estimate is 3.1 percentage points above the measured one; the range from low to high includes it.
By their numbers in this assay, from the lowest: compounds 3, 1, 4 and 2 (each within the scatter of the next).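

In this assay, hydrogen in place of trifluoromethyl on an aromatic carbon gives a number 5.9 percentage points higher from compound 3 to compound 4 (within the scatter), and hydrogen in place of chloro on an aromatic carbon gives a number 1.3 percentage points lower from compound 2 to compound 4 (within the scatter). Going by these compounds alone, these are the first steps that differ in one place, and they show that the terminal ring can lose either group with no reading beyond the scatter, at this one concentration. No measurement at hand explains these readings.

The compounds shown leave open whether the reading would hold with no trifluoromethyl left on that ring, or with an amine or a carboxylic acid on the same aromatic carbon. They also leave open what a single reading at one concentration cannot give, namely how the potencies of these ureas compare.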